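The source may hold more compounds than are shown below. What is called first, only, known or untested is meant among the compounds shown, and "the series" means these compounds.

Of the compounds shown here, three have been tested in an ADME assay on HEK293 cells (Homo sapiens) for cytotoxicity, read by MTT assay, with a stated time of 48 h (on this read-out higher numbers stand for weaker inhibition and lower numbers for stronger inhibition), so far. Compound 1 `Cc1ccc(/C=C2/S/C(=N/c3ccccc3)N(Cc3ccncc3)C2=O)cc1` gives 49500 nM. Compound 2 `O=C1/C(=C\c2ccc(O)cc2)S/C(=N/c2ccccc2)N1Cc1ccncc1` gives 142000 nM, and compound 3 `CN(C)c1ccc(/C=C2/S/C(=N/c3ccccc3)N(Cc3ccncc3)C2=O)cc1` gives 122000 nM. Among these, compound 2 stands at the highest of the three numbers, though its nearest neighbour, compound 3, lies within the scatter of it a 1.2-fold lower number from compound 2 to compound 3 (0.07 log units; within the scatter), so no order between those two can be read from the data; compound 1 is the furthest from compound 2, as the step of a 2.9-fold higher number from compound 1 to compound 2 (0.46 log units; beyond the scatter) shows.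

The next compound, compound 4 `O=C1/C(=C\c2cccc(O)c2)S/C(=N/c2ccccc2)N1Cc1ccncc1`, is related to compound 2 by the following change: 3-hydroxyphenyl in place of 4-hydroxyphenyl on a double-bonded chain carbon bound to a double-bonded ring carbon. Within the data shown here, the measured steps all concern what group sits on the aromatic ring in compound 1, compound 2 and compound 3 (a 2.9-fold higher number from compound 1 to compound 2 (0.46 log units; beyond the scatter) and a 2.5-fold higher number from compound 1 to compound 3 (0.39 log units; beyond the scatter)), and none of them describes moving a group from one place on that ring to another, so no measured step bears directly on this change. With nothing in the data pointing either way, the account expects a step in this assay of no clear direction, and within the usual scatter, from compound 2 to compound 4 a 1.0-fold lower number from compound 2 to compound 4 (0.01 log units; within the scatter). Compound 4 is therefore estimated at 140000 nM, with a range from 60000 nM to 320000 nM.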

Compound 4, half-maximal inhibitory concentration: 150000 nM
The estimate for compound 4 lay 1.1-fold (0.03 log units) below the measured number, within the range that was stated.
By their numbers in this assay, from the lowest: compound 1; then compounds 3, 2 and 4 (each within the scatter of the next).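

In this assay, the 3-hydroxyphenyl group in place of the 4-hydroxyphenyl group on a double-bonded chain carbon bound to a double-bonded ring carbon gives a 1.1-fold higher number from compound 2 to compound 4 (0.02 log units; within the scatter), so this first change in where the hydroxy group sits on the aromatic ring leaves no readable difference. Compound 4 also cannot be told apart from the 4-(dimethylamino)phenyl compound, with a 1.2-fold higher number from compound 3 to compound 4 (0.09 log units; within the scatter), whereas the 4-methylphenyl compound stands apart, with a 3.0-fold higher number from compound 1 to compound 4 (0.48 log units; beyond the scatter); among these four compounds, then, only compound 1 is separated from the others, and both hydroxy placements share that separation from it. Nothing available here offers an explanation for this pattern.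

The compounds shown leave open whether a change of place on the aromatic ring would prove equally unreadable for a group other than hydroxy, since this is the only group for which such a change is seen. They also leave open how a carboxylic acid, an amine or a longer chain such as propyl on that ring would compare with the methyl group of compound 1 and the hydroxy group of compound 2.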